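A bromo-substituted core with an aminophenyl group exchanged for a chain

The source may hold more compounds than are shown below. What is called first, only, known or untested is meant among the compounds shown, and "the series" means these compounds.

The account follows a small set of compounds sharing one core, all examined in a functional assay on HCT-116 cells (Homo sapiens) for cytotoxicity, read by MTT assay, with a stated time of 72 h; on this read-out lower numbers stand for stronger inhibition and higher numbers for weaker inhibition. For the measured compounds named here, compound 1 `Nc1ccc(Nc2c(C(=O)NCc3ccc(F)cc3)nc(Br)c3cccnc23)cc1` is the only member of the set that gives a single number: in this assay compound 1 gives 10000 nM. Compound 3 `N[C@H]1CC[C@H](Nc2c(C(=O)NCc3ccc(F)cc3)nc(N3CCCCS3(=O)=O)c3cccnc23)CC1` carries a different group on the core and a cyclohexane-based amine in place of the aminophenyl amine; for compound 3 in this assay the result is recorded only as a limit of the assay, > 10000 nM. That limit is described as the limit of > 10000 nM in this assay, at which 1 of the 3 values shown sits. Compound 2 `CN(C)c1ccc(CNC(=O)c2nc(Br)c3cccnc3c2N[C@H]2CC[C@H](N)CC2)cc1` was included in the study, but in this assay compound 2 gives "not determined" (no result reported).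

Compound 4 `CN(C)CCCNc1c(C(=O)NCc2ccc(F)cc2)nc(Br)c2cccnc12` is not yet measured. It differs from compound 1 in one place: 3-(dimethylamino)propyl in place of 4-aminophenyl on a nitrogen on an aromatic ring

Going by the values given here, no step between measured compounds exists to guide the size of this change, since compound 3 differs from compound 1 in two places and compound 2 has no result. Compound 1 itself sits at weak inhibition, so the expected step from compound 1 to compound 4 in this assay is small, a 1.1-fold lower number from compound 1 to compound 4 (0.05 log units; within the scatter), and is not expected to exceed the usual scatter. For compound 4 in this assay the estimated value is 9000 nM, expected to fall between 2500 nM and 30000 nM.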

Compound 4, half-maximal inhibitory concentration: > 10000 nM
Compound 4 gave a limit, no number; the forecaster's own chance of this, stated with the estimate: 40%; middle value at least 1.1-fold (0.04 log units) from the limit.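

In this assay the exchange of 4-aminophenyl for 3-(dimethylamino)propyl gives a number no lower from compound 1 to compound 4 (the limit leaves the size open) on a nitrogen on an aromatic ring. This is the only step shown in which a single place changes, and it shows that replacing the aromatic ring of compound 1 with this open chain brings no stronger inhibition. Compound 4 reads only as a limit of the assay, and it is the second entry in the set to do so: the limit of > 10000 nM in this assay, at which 2 of the 4 values shown sit.

On these data alone, the real distance between compound 4 and compound 1 stays open, as does whether any group on this nitrogen can give clearly stronger inhibition than compound 1. A 4-hydroxyphenyl group, a shorter chain ending in a primary amine, or a propyl chain ending in a morpholine ring does not appear among these compounds, and neither does a one-place exchange of the bromine on the shared core.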